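Trimming a methoxy from compound 3

The source may hold more compounds than are shown below. What is called first, only, known or untested is meant among the compounds shown, and "the series" means these compounds.

Measured in a functional assay on MOLT-4 cells (Homo sapiens) for antiproliferative activity; on this read-out lower numbers stand for stronger inhibition and higher numbers for weaker inhibition:
compound 1, `COc1cc(C(=O)c2sc(-c3cccs3)cc2N)cc(OC)c1OC`: 8.9 nM
compound 2, `COc1cc(C(=O)c2sc(-c3cccc([N+](=O)[O-])c3)cc2N)cc(OC)c1OC`: 7.5 nM
compound 3, `COc1ccc(-c2cc(N)c(C(=O)c3cc(OC)c(OC)c(OC)c3)s2)cc1OC`: 20 nM

Compound 3 holds the highest number of the three in this assay; compound 1 lies nearest, compound 2 furthest, both beyond the scatter. Compound 4, `COc1cccc(-c2cc(N)c(C(=O)c3cc(OC)c(OC)c(OC)c3)s2)c1`, differs from compound 3 by hydrogen in place of methoxy on an aromatic carbon. Among the compounds with values here, no measured step removes a methoxy in this way. The bearing steps are a 2.2-fold higher number from compound 1 to compound 3 (0.35 log units; beyond the scatter) and a 2.7-fold higher number from compound 2 to compound 3 (0.43 log units; beyond the scatter), which show the 3,4-dimethoxyphenyl ring giving modestly higher numbers than two other aryl groups. Moving toward a smaller ring, a small lowering is expected, at or just beyond the scatter: a 1.4-fold lower number from compound 3 to compound 4 (0.15 log units; within the scatter). Compound 4 is therefore estimated at 14 nM, within 6 nM to 35 nM.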

Compound 4, half-maximal inhibitory concentration: 17 nM
Compound 4: middle estimate off by 1.2-fold (0.08 log units), on the low side; low and high end bracket the measured number.
By their numbers in this assay, from the lowest: compounds 2, 1, 4 and 3 (each within the scatter of the next, the first and the last beyond it).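

In this assay, going from 3,4-dimethoxyphenyl to 3-methoxyphenyl gives a 1.2-fold lower number from compound 3 to compound 4 (0.07 log units; within the scatter), so this methoxy can give way to hydrogen without a change that stands clear of the scatter. The 3-methoxyphenyl ring still shows a 2.3-fold higher number from compound 2 to compound 4 (0.36 log units; beyond the scatter), whereas a 1.9-fold higher number from compound 1 to compound 4 (0.28 log units; within the scatter) stays inside the scatter. Nothing measured here bears on the reason for these results. The compounds shown leave open how a hydroxy group, a fluorine or an amine would fare on this carbon. Going by these compounds, whether the remaining methoxy could also give way to hydrogen stays open too.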